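Thioether anilides: triazole to tetrazole swap on sulfur

A few compounds are considered here, and "the series" means these few. Any claim that something is new, unique, unknown or untested is made for them only; others in the source may bear on it.

Measured so far:
- compound 1 `Cn1c(-c2ccc(NC(=O)CCl)cc2)nc(-c2ccccc2)c1-c1ccccc1`: 15.1%
- compound 2 `Cn1cnnc1SCC(=O)Nc1ccc(-c2nc(-c3ccccc3)c(-c3ccccc3)n2C)cc1`: 43.1%

Both numbers come from a functional assay on HT-29 cells (Homo sapiens) for cytotoxicity, read by MTT assay, with a stated time of 24 h, tested at 6.4 ug/mL; a lower number here means a weaker effect, a higher number a stronger effect of the compound at the concentration tested. For the measured compounds named here, compound 2 stands highest of the two, with compound 1 the only neighbour and a number lower; the one step in hand is a number 28 percentage points higher from compound 1 to compound 2 (beyond the scatter), which replaces chloro on a saturated chain carbon bound to a carbonyl carbon by (4-methyl-4H-1,2,4-triazol-3-yl)sulfanyl.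

Compound 3 `Cn1nnnc1SCC(=O)Nc1ccc(-c2nc(-c3ccccc3)c(-c3ccccc3)n2C)cc1` is not yet measured. It differs from compound 2 by 1-methyl-1H-tetrazol-5-yl in place of 4-methyl-4H-1,2,4-triazol-3-yl on a sulfur. This change, one aromatic ring for another on the same sulfur, is not covered by any measured step: the step from compound 1 to compound 2 concerns what hangs on the chain carbon, not an exchange between two five-membered rings already bound there, so it gives no direction for the present swap.

With nothing in the series speaking for a shift either way, the expected step is none beyond the scatter, i.e. a number 0.1 percentage points lower from compound 2 to compound 3 (within the scatter) for compound 3 in this assay. As far as these compounds go, the estimate for compound 3 is therefore 43%, with a range from 25% to 60%, kept wide because the ring exchange itself is untested here.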

Compound 3, a percentage reported as activity, at one concentration (the size of the read-out at that concentration, not a potency): 60.6%
Compound 3: middle estimate off by 17.6 percentage points, on the low side; measured number outside the range, above it.
By their numbers in this assay, from the lowest: compound 1; then compound 2; then compound 3.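

In this assay, the identity of the ring on the sulfur matters: with the saturated chain carbon, the carbonyl and the shared core unchanged, 1-methyl-1H-tetrazol-5-yl in place of 4-methyl-4H-1,2,4-triazol-3-yl gives a number 17.5 percentage points higher from compound 2 to compound 3 (beyond the scatter), and this step beyond the scatter arises with no change in heavy atom count, the two groups differing in the hetero atoms of the ring. Set against chloro on the chain carbon, (1-methyl-1H-tetrazol-5-yl)sulfanyl gives a number 45.5 percentage points higher from compound 1 to compound 3 (beyond the scatter), a larger step than the one to the triazole group, a number 28 percentage points higher from compound 1 to compound 2 (beyond the scatter), so the gain over chloro depends on which ring the sulfur carries.

Still open, as far as these compounds go, is whether the ring is needed at all, or whether a plain methylsulfanyl, a tetrazole without its methyl, or an amine on the chain carbon would hold the read-out at this level. Also open, from the compounds shown here alone, are the effect of a longer chain between sulfur and carbonyl and whether the order of the three compounds persists at other concentrations, since each read-out is a single-concentration figure and not a potency.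

No supporting data bear on why the tetrazole group reads higher than the triazole group.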